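Ester side chain in place of the benzyl phenyl

The source may report more compounds than this note shows. Statements on the series, on what has been measured and on what is new or still open speak of the compounds shown alone.

Measured so far in a functional assay on CHO cells for inhibition of transient receptor potential cation channel subfamily V member 1 (Homo sapiens); on this read-out lower numbers stand for stronger inhibition and higher numbers for weaker inhibition:
- compound 1 `CC(C)(C)c1ccc(/C(=C/C(=O)Nc2ccc3c(c2)OCCO3)c2cccnc2)cc1` gives 78 nM
- compound 2 `CC(C)C/C(=C\C(=O)Nc1ccc2c(c1)OCCO2)c1ccc(C(C)(C)C)cc1` gives 16 nM
- compound 3 `CC(C)(C)c1ccc(/C(=C/C(=O)Nc2ccc3c(c2)OCCO3)Cc2ccccc2)cc1` gives 14 nM

Compound 3 carries the lowest number of the three, but the step of a 1.1-fold lower number from compound 2 to compound 3 (0.06 log units; within the scatter) is within the scatter; only against compound 1 does it stand apart, by a 5.6-fold lower number from compound 1 to compound 3 (0.75 log units; beyond the scatter). The step to compound 4 `CCOC(=O)CC/C(=C\C(=O)Nc1ccc2c(c1)OCCO2)c1ccc(C(C)(C)C)cc1` is (ethoxycarbonyl)methyl in place of phenyl on a saturated chain carbon bound to a double-bonded chain carbon. Going by the values given here, two measured steps bear on the position concerned: the change at the double-bonded chain carbon, a 4.9-fold lower number from compound 1 to compound 2 (0.69 log units; beyond the scatter) and a 5.6-fold lower number from compound 1 to compound 3 (0.75 log units; beyond the scatter), both modest, and the change at the saturated chain carbon, a 1.1-fold lower number from compound 2 to compound 3 (0.06 log units; within the scatter), which was within the scatter. Nothing measured introduces an ester at this place, so the expectation rests on the observation that phenyl and isopropyl at the same place gave near-identical numbers in this assay. A small step is therefore expected for compound 4, most likely towards a somewhat higher number, with the expected step being a 1.8-fold higher number from compound 3 to compound 4 (0.25 log units; within the scatter). Compound 4 is estimated at 25 nM, with a range from 8 nM to 80 nM.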

Compound 4, half-maximal inhibitory concentration: 36 nM
Compound 4: middle estimate off by 1.4-fold (0.16 log units), on the low side; the measured number falls inside the stated range.
By their numbers in this assay, from the lowest: compounds 3 and 2 (each within the scatter of the next); then compound 4; then compound 1.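

In this assay, going by these compounds alone, (ethoxycarbonyl)methyl is the only change at the saturated chain carbon that moves the number beyond the scatter (a 2.6-fold higher number from compound 3 to compound 4 (0.41 log units; beyond the scatter); a 2.3-fold higher number from compound 2 to compound 4 (0.35 log units; beyond the scatter)), both steps modest, whereas phenyl and isopropyl at this place could not be told apart. The place is thus not indifferent to what it carries, yet the ester chain still keeps compound 4 ahead of the pyridin-3-yl analogue (a 2.2-fold lower number from compound 1 to compound 4 (0.34 log units; beyond the scatter)), also a modest step. No measurement at hand accounts for the rise in the number.

Open, from the compounds shown here alone, is whether the step follows the ester carbonyl or the ethyl end of the chain. A carboxylic acid, a methyl ester or a plain unbranched alkyl chain at this place would separate the two.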